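The compounds below may be only part of what the source reports. "The series", "measured", "known", "first", "only" and "open" are said of these compounds alone.

Three compounds have numbers so far in a functional assay on PC-3 cells (Homo sapiens) for antiproliferative activity, read by MTT assay; a higher number here means a weaker inhibitor, a lower number a stronger inhibitor:

Compound 1, `Cn1c(=O)c(=O)n(C2CCCC2)c2nc(N/N=C/c3ccc(O)cc3)ncc21`, gives > 100000 nM, which is a limit of the assay and not a number.
Compound 2, `Cn1c(=O)c(=O)n(C2CCCC2)c2nc(N/N=C/c3ccc(Cl)cc3)ncc21`, gives 8420 nM.
Compound 3, `Cn1c(=O)c(=O)n(C2CCCC2)c2nc(N/N=C/c3ccc(C(F)(F)F)cc3)ncc21`, gives 23600 nM.

Compound 2 holds the lowest of the two real numbers; its nearest neighbour is compound 3, with a 2.8-fold higher number from compound 2 to compound 3 (0.45 log units; beyond the scatter). Compound 1 sits at the limit of the assay (the limit of > 100000 nM in this assay, at which 1 of the 3 values shown sits).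

The next compound, compound 4, `Cn1c(=O)c(=O)n(C2CCCC2)c2nc(N/N=C/c3ccc(F)cc3F)ncc21`, differs from compound 2 in one place: 2,4-difluorophenyl in place of 4-chlorophenyl on a carbon with a double bond to nitrogen.

Which steps bear on this? Exchanging the hydroxy for a halogen or a trifluoromethyl gave an at least 11-fold lower number from compound 1 to compound 2 (1.07 log units; beyond the scatter) and an at least 4.2-fold lower number from compound 1 to compound 3 (0.62 log units; beyond the scatter). Exchanging one halogen-type group for another gave a 2.8-fold higher number from compound 2 to compound 3 (0.45 log units; beyond the scatter). Among the compounds with values here, no measured step shows a fluorine or a second substituent on that ring, so the evidence is indirect. The closest comparison is the modest step from chloro to trifluoromethyl, which suggests that moving from chloro to 2,4-difluorophenyl will also be a modest step, most likely towards a higher number in this assay.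

Compound 4 is therefore expected to give 15000 nM, within a range from 5000 nM to 45000 nM, which is an estimated 1.8-fold higher number from compound 2 to compound 4 (0.25 log units; within the scatter).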

Compound 4, half-maximal inhibitory concentration: 13200 nM
Beside the measured number, compound 4's estimate is 1.1-fold (0.06 log units) above it, within the range that was stated.
By their numbers in this assay, from the lowest: compounds 2, 4 and 3 (each within the scatter of the next, the first and the last beyond it). At a limit, above all of these: compound 1.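

In this assay, the change from chloro to a ring with two fluorines gives a 1.6-fold higher number from compound 2 to compound 4 (0.20 log units; within the scatter), and the change from trifluoromethyl gives a 1.8-fold lower number from compound 3 to compound 4 (0.25 log units; within the scatter), so compound 4 cannot be told apart from either neighbour, even though compound 2 and compound 3 differ from each other beyond the scatter. Within the data shown here, this is the first sign that this position accepts a ring with more than one substituent and a fluorine in place of chloro, without a clear change in the read-out, and the comparison with the hydroxy compound gives an at least 7.5-fold lower number from compound 1 to compound 4 (0.87 log units; beyond the scatter). That step rests on a limit and not a number, as compound 1 has no measured value: the limit of > 100000 nM in this assay, at which 1 of the 4 values shown sits.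

The compounds shown leave open what a single fluorine would give, so the 4-fluorophenyl compound would be needed to separate the effect of one fluorine from that of two. Also open, from the compounds shown here alone, is how a ring carrying an amine, a methoxy group or a nitrile would compare with compound 2 at 8420 nM.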